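Aryl change from compound 3 to compound 4

A few compounds are considered here, and "the series" means these few. Any claim that something is new, unique, unknown or untested is made for them only; others in the source may bear on it.

In a functional assay on MDA-MB-231 cells (Homo sapiens) for antiproliferative activity, read by MTT assay, with a stated time of 48 h (on this read-out higher numbers stand for weaker inhibition and lower numbers for stronger inhibition), compound 1 `C=CS(=O)(=O)N1CCN(c2ncnc3sc(-c4ccc(N5CCN(C)CC5)cc4)cc23)CC1` gives 7550 nM, compound 2 `CN1CCN(c2ccc(-c3cc4c(N5CCN(C(=O)Nc6ccccc6)CC5)ncnc4s3)cc2)CC1` gives 7590 nM and compound 3 `CN1CCN(c2ccc(-c3cc4c(N5CCN(C(=O)Nc6cccc(F)c6)CC5)ncnc4s3)cc2)CC1` gives 13200 nM. All three lie within the scatter of one another, so compound 3 does not stand apart. Compound 4 `COc1ccccc1NC(=O)N1CCN(c2ncnc3sc(-c4ccc(N5CCN(C)CC5)cc4)cc23)CC1` follows from compound 3 by 2-methoxyphenyl in place of 3-fluorophenyl on an amide-type nitrogen. The nearest measured evidence is the aryl fluoro change, a 1.7-fold higher number from compound 2 to compound 3 (0.24 log units; within the scatter). Replacing vinylsulfonyl gave a 1.0-fold higher number from compound 1 to compound 2 (0.00 log units; within the scatter) and a 1.7-fold higher number from compound 1 to compound 3 (0.24 log units; within the scatter). Going by the values given here, no measured compound carries 2-methoxyphenyl, so these steps bear on it only indirectly. No change beyond the scatter is expected in this assay, and the expected step is a 1.3-fold lower number from compound 3 to compound 4 (0.12 log units; within the scatter). Compound 4 is estimated at 10000 nM, with an expected range of 4500 nM to 22000 nM.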

Compound 4, half-maximal inhibitory concentration: 23200 nM
Compound 4: the middle estimate sits 2.3-fold (0.37 log units) below what was measured; measured number above the stated range.
By their numbers in this assay, from the lowest: compounds 1, 2, 3 and 4 (each within the scatter of the next, the first and the last beyond it).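

In this assay 2-methoxyphenyl on the amide-type nitrogen gives a 1.8-fold higher number from compound 3 to compound 4 (0.24 log units; within the scatter) and so does not separate from 3-fluorophenyl. Going by these compounds alone, the added methoxy gives a 3.1-fold higher number from compound 2 to compound 4 (0.49 log units; beyond the scatter) and (2-methoxyphenyl)carbamoyl in place of vinylsulfonyl gives a 3.1-fold higher number from compound 1 to compound 4 (0.49 log units; beyond the scatter) as the first steps beyond the scatter, both modest and both towards weaker inhibition. Nothing measured here accounts for these steps.

Open, from the compounds shown here alone, is whether an amine or a carboxylic acid on this aryl ring would leave the number in the same range or move it in either direction.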